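Chloromethylbenzyl purines: cytotoxicity on colon carcinoma cells

The compounds below may be only part of what the source reports. "The series", "measured", "known", "first", "only" and "open" are said of these compounds alone.

Measured so far:
compound 1 `ClCc1ccc(Cn2cnc3c(Cl)ncnc32)cc1` gives 63100 nM
compound 2 `ClCc1ccc(Cn2cnc3nc(Cl)nc(Cl)c32)cc1` gives 6760 nM
compound 3 `ClCc1cccc(Cn2cnc3c(Cl)nc(Cl)nc32)c1` gives > 100000 nM

The read-out throughout is a functional assay on HCT-15 cells (Homo sapiens) for cytotoxicity, read by sulforhodamine B assay, with a stated time of 48 h; on this read-out higher numbers stand for lower toxicity in this test and lower numbers for higher toxicity in this test. Among the two numbers, compound 1 holds the highest; the nearest is compound 2, whose number sits lower by a gap beyond the scatter. Compound 3 returns only a limit of the assay the limit of > 100000 nM in this assay, at which 1 of the 3 values shown sits, and gives no number.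

Compound 4 `ClCc1ccc(Cn2cnc3c(Cl)nc(Cl)nc32)cc1` remains to be measured. It differs from compound 1 by chloro in place of hydrogen on an aromatic carbon; the new chloro sits between two ring nitrogen atoms, meta to a chloro group, meta to a fused ring and para to a fused ring. Among the compounds with values here, no step between measured compounds covers this single change. Compound 2 and compound 3 each carry two chloro groups on the shared core and point in opposite directions, one toward a lower number, one to a limit, so the expected step is modest and uncertain. The estimated step from compound 1 to compound 4 is a 2.1-fold lower number from compound 1 to compound 4 (0.32 log units; beyond the scatter), toward a somewhat lower number. Compound 4 is expected at 30000 nM, between 5000 nM and 150000 nM.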

Compound 4, concentration lethal to 50% of the cells: 7590 nM
Compound 4: middle estimate off by 4.0-fold (0.60 log units), on the high side, and the stated range covers the measured number.
By their numbers in this assay, from the lowest: compounds 2 and 4 (each within the scatter of the next); then compound 1. At a limit, above all of these: compound 3.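

In this assay, within the data shown here, the chloro that enters between two ring nitrogen atoms, meta to a chloro group, gives an 8.3-fold lower number from compound 1 to compound 4 (0.92 log units; beyond the scatter), the first step that can be read for a single change, so this position on the shared core does register on this read-out. Compound 4 at 7590 nM and compound 2 at 6760 nM both carry two chloro groups on the shared core, and their values lie within the scatter of each other. Compound 3 remains a limit of the assay, so no step involving it can be read: the limit of > 100000 nM in this assay, at which 1 of the 4 values shown sits.

The compounds shown leave open whether this step belongs to chloro in particular or would also follow from another group on the same aromatic carbon, such as an amine, a methoxy group or a methyl group. They also leave open how much of the cytotoxicity depends on the chloromethyl group, which all four compounds carry and which a hydroxymethyl or a plain methyl group in its place would test.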